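A trifluoromethoxy group added to the weakest sulfonyl aryl

A few compounds are considered here, and "the series" means these few. Any claim that something is new, unique, unknown or untested is made for them only; others in the source may bear on it.

Of the compounds shown here, three sharing one core have been measured in a functional assay on CHO cells for antagonist activity at 5-hydroxytryptamine receptor 6 (Homo sapiens), read by FLIPR; a lower number here means a stronger inhibitor, a higher number a weaker inhibitor. Compound 1 `CN1CCC(N(C)C(=O)C2CN(S(=O)(=O)c3cccc4c(Cl)cccc34)c3ccccc32)CC1` gives 5.01 nM. Compound 2 `CN1CCC(N(C)C(=O)C2CN(S(=O)(=O)c3ccc4c(c3)OCCO4)c3ccccc32)CC1` gives 50.1 nM. Compound 3 `CN1CCC(N(C)C(=O)C2CN(S(=O)(=O)c3ccccc3)c3ccccc32)CC1` gives 316 nM, the highest of the three numbers: the step of a 63-fold higher number from compound 1 to compound 3 (1.80 log units; beyond the scatter) is large, and the step of a 6.3-fold higher number from compound 2 to compound 3 (0.80 log units; beyond the scatter) is modest, so compound 3 stands as the weakest of the measured set.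

Compound 4 `CN1CCC(N(C)C(=O)C2CN(S(=O)(=O)c3ccc(OC(F)(F)F)cc3)c3ccccc32)CC1` has not yet been measured. It differs from compound 3 by trifluoromethoxy in place of hydrogen on an aromatic carbon, on an aromatic carbon of the six-membered aromatic ring of carbon only that sits on the sulfonyl sulfur.

For the measured compounds named here, the steps that bear on this change are those in which the same ring was replaced by a larger aryl group: a 63-fold higher number from compound 1 to compound 3 (1.80 log units; beyond the scatter) and a 6.3-fold higher number from compound 2 to compound 3 (0.80 log units; beyond the scatter) both ran toward higher numbers when the ring lost its substitution. Compound 4 keeps the ring of compound 3 and adds a single trifluoromethoxy group, so a step back toward a lower number, smaller than either of those, is expected. He therefore expects for compound 4 a value of about 100 nM, within a range from 32 nM to 316 nM, which is an expected step of a 3.2-fold lower number from compound 3 to compound 4 (0.50 log units; beyond the scatter).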

Compound 4, inhibition constant: 20 nM
Compound 4: the middle estimate sits 5.0-fold (0.70 log units) above what was measured; the measured number lies below the stated range.
By their numbers in this assay, from the lowest: compound 1; then compound 4; then compound 2; then compound 3.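

In this assay, for the compounds shown here, adding one trifluoromethoxy group to the phenyl ring, para to a large group, gives a 16-fold lower number from compound 3 to compound 4 (1.20 log units; beyond the scatter), the first sign that this ring can respond strongly to a single substituent; the earlier steps exchanged the whole aryl group on the sulfonyl sulfur and could not show this. Set against those larger aryl groups, the 4-(trifluoromethoxy)phenyl group gives a 2.5-fold lower number from compound 2 to compound 4 (0.40 log units; beyond the scatter) and a 4.0-fold higher number from compound 1 to compound 4 (0.60 log units; beyond the scatter), so a substituted phenyl ring covers much of the distance to the 5-chloronaphthalen-1-yl compound without matching it. Nothing available here explains why this group has so large an effect.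

The compounds shown carry only this one substituent on the phenyl ring, so they leave open whether the gain belongs to trifluoromethoxy itself or would also appear with a methoxy group, a chlorine atom or a nitrile in the same place. They also leave open whether trifluoromethoxy would give a similar step on another carbon of the ring.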